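The compounds below may be only part of what the source reports. "The series", "measured", "known", "first", "only" and "open" are said of these compounds alone.

Compound 1 `Oc1ccc(-c2cc(-c3ccc(Cl)cc3)nc(-c3cccnc3)c2)cc1` gives 20700 nM in a functional assay on HCT-15 cells (Homo sapiens) for cytotoxicity, read by CCK-8 assay and cell counting, with a stated time of 2 days; a higher number here means a weaker inhibitor, a lower number a stronger inhibitor. Compound 2 `Oc1ccc(-c2cc(-c3cccnc3)nc(-c3cccc(Cl)c3)c2)cc1` gives 21300 nM in this assay; the change 3-chlorophenyl in place of 4-chlorophenyl on an aromatic carbon made a 1.0-fold higher number from compound 1 to compound 2 (0.01 log units; within the scatter). Compound 3 `Oc1ccc(-c2cc(-c3ccc(Cl)cc3)nc(-c3ccco3)c2)cc1` gives 7020 nM in this assay; its core differs from that of compound 1 by furan-2-yl in place of pyridin-3-yl on an aromatic carbon, and this change made a 2.9-fold lower number from compound 1 to compound 3 (0.47 log units; beyond the scatter), leaving compound 3 with the lowest of the three numbers.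

Compound 4 `Oc1ccc(-c2cc(-c3cccc(Cl)c3)nc(-c3ccco3)c2)cc1` is not yet measured. Its difference from compound 3 is 3-chlorophenyl in place of 4-chlorophenyl on an aromatic carbon. Around the place, compound 4 is meta to a furan-2-yl group where compound 2 is meta to a pyridin-3-yl group, so this is the same kind of change as from compound 1 to compound 2, not the same one. Because the step of a 1.0-fold higher number from compound 1 to compound 2 (0.01 log units; within the scatter) lies within the scatter, an expected step of a 1.0-fold higher number from compound 3 to compound 4 (0.01 log units; within the scatter) follows. Compound 4 is therefore estimated at 7200 nM in this assay, within 3600 nM to 14500 nM.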

Compound 4, half-maximal inhibitory concentration: 8020 nM
Beside the measured number, compound 4's estimate is 1.1-fold (0.05 log units) below it; the measured number falls inside the stated range.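

In this assay, 3-chlorophenyl in place of 4-chlorophenyl makes a 1.1-fold higher number from compound 3 to compound 4 (0.06 log units; within the scatter), and this change carries from one core to the other: the same change on two cores in this assay, a 1.0-fold higher number (0.01 log units; within the scatter) from compound 1 to compound 2 and a 1.1-fold higher number (0.06 log units; within the scatter) from compound 3 to compound 4, 1.1-fold (0.05 log units) apart, within the scatter of two such steps

Furan-2-yl in place of pyridin-3-yl makes a 2.7-fold lower number from compound 2 to compound 4 (0.42 log units; beyond the scatter), and this change carries across as well: the same change on two cores in this assay, a 2.9-fold lower number (0.47 log units; beyond the scatter) from compound 1 to compound 3 and a 2.7-fold lower number (0.42 log units; beyond the scatter) from compound 2 to compound 4, 1.1-fold (0.05 log units) apart, within the scatter of two such steps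

Among these compounds, these four compounds give only one pair of steps for each change, so they do not show that either step would hold on a core with other groups or in other cells.

Still open, on these data alone, is what happens when the 4-hydroxyphenyl group is changed, for example to a 4-methoxyphenyl or 4-aminophenyl group. Also open, as far as these compounds go, is whether a thiophen-2-yl group would behave like furan-2-yl.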